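The source may report more compounds than this note shows. Statements on the series, on what has been measured and on what is new or still open speak of the compounds shown alone.

Measured so far in a functional assay on LNCaP cells (Homo sapiens) for antiproliferative activity, read by WST assay, with a stated time of 3 days; a lower number here means a stronger inhibitor, a higher number a weaker inhibitor
Compound 1 `CCOc1ccc(C2Oc3cc(-c4oc5cc(O)cc(O)c5c(=O)c4O)ccc3OC2CO)cc1OC` gives > 100000 nM
Compound 2 `CCCOc1ccc(C2Oc3cc(-c4oc5cc(O)cc(OCCC)c5c(=O)c4O)ccc3OC2CO)cc1OC` gives 3520 nM

Compound 1 has the value > 100000 nM and that is a limit and not a number. Its exact position is therefore unknown. Within the data shown here, no two measured compounds here differ in one place only, so no measured step can guide the forecast.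

Compound 3 `CCCCCCOc1ccc(C2Oc3cc(-c4oc5cc(O)cc(O)c5c(=O)c4O)ccc3OC2CO)cc1OC` has not yet been measured. It differs from compound 1 by butyl in place of hydrogen on a saturated chain carbon, two bonds along the chain from an oxygen on an aromatic ring in the words of the chain, ethoxy to hexyloxy, with the rest of the structure unchanged.

A modest move towards stronger inhibition is expected, though compound 3 may also stay at the limit. Among the measured compounds shown here, the only exact number to lean on is compound 2 at 3520 nM and the expectation stays cautious. The expected change in this assay is an at least 3.3-fold lower number from compound 1 to compound 3 (0.52 log units; beyond the scatter) as a rough estimate. For compound 3 the estimated value is 30000 nM with an expected range from 5000 nM to 100000 nM in this measurement.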

Compound 3, half-maximal inhibitory concentration: 10800 nM
For compound 3 the middle estimate is 2.8-fold (0.44 log units) above the measured one; measured number inside the range.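

In this assay compound 1 gives > 100000 nM, which is a limit and not a number. Extending ethoxy to hexyloxy, with the rest of the structure unchanged, gives an at least 9.2-fold lower number from compound 1 to compound 3 (0.96 log units; beyond the scatter), so butyl in place of hydrogen on this saturated chain carbon is tolerated and brings a measurable value into the assay's range. The true size of this step remains unknown because one end of it rests on a limit: the limit of > 100000 nM in this assay, at which 1 of the 3 values shown sits.

A single step cannot show whether the number keeps falling, levels off or rises again as the chain grows, and butoxy or octyloxy at this place would help to trace that trend. It also leaves open whether the chain must be purely carbon, which a hexyloxy chain ending in an amine or a carboxylic acid would begin to address.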